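Trichlorophenyl for Ethoxyphenyl at the Edge of Detection

The source may report more compounds than this note shows. Statements on the series, on what has been measured and on what is new or still open speak of the compounds shown alone.

Compound 3 `CCOc1ccc(-n2nncc2CN2C(=O)C3(C(C#N)=C(N)Oc4c(N)cc5nc6ccccc6nc5c43)c3ccccc32)cc1` was examined in a functional assay on A549 cells (Homo sapiens) for antiproliferative activity, read by MTT assay, with a stated time of 48 h; a higher number here means a weaker inhibitor, a lower number a stronger inhibitor. In this assay compound 3 gives > 50000 nM, which is a limit of the assay and not a number. For comparison, compound 1 `N#CC1=C(N)Oc2c(c3nc4ccccc4nc3c3ccccc23)C12C(=O)N(Cc1cnnn1-c1ccccc1Cl)c1ccccc12` gives 42600 nM in this assay. Compound 2 `CC(=O)Nc1ccc(-n2nncc2CN2C(=O)C3(C(C#N)=C(N)Oc4c3c3nc5ccccc5nc3c3ccccc43)c3ccccc32)cc1` gives > 50000 nM in this assay, again a limit of the assay rather than a number. Within the data shown here, the one step between measured compounds that changes a single place, an at least 1.1-fold higher number from compound 1 to compound 2 (0.06 log units; that floor lies within the scatter), swaps the aryl group on the aromatic nitrogen, and its size is bounded by the limit of > 50000 nM in this assay, at which 2 of the 3 values shown sit. Compound 4 `N#CC1=C(N)Oc2c(N)cc3nc4ccccc4nc3c2C12C(=O)N(Cc1cnnn1-c1c(Cl)cc(Cl)cc1Cl)c1ccccc12` differs from compound 3 by 2,4,6-trichlorophenyl in place of 4-ethoxyphenyl on an aromatic nitrogen. Among the measured compounds shown here, that step from compound 1 to compound 2 is the only measured guide, and compound 1, which carries a 2-chlorophenyl group, is itself a weak inhibitor, so there is no ground to expect a stronger inhibitor from a trichlorophenyl group. Compound 4 is therefore expected to give about 50000 nM in this assay, within a range from 25000 nM to 100000 nM, most likely reported as a limit. The expected step is a number no higher from compound 3 to compound 4 (the limit leaves the size open), essentially none beyond the scatter.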

Compound 4, half-maximal inhibitory concentration: > 50000 nM
Compound 4 gave a limit, no number (the forecaster's own chance of this, stated with the estimate: 60%); the middle value sits exactly at the limit.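

Among these compounds, compound 3 and compound 4 each end at a limit of the assay and not at a number, so no step between them can be read: the limit of > 50000 nM in this assay, at which 3 of the 4 values shown sit.

The compounds shown leave open whether 4-ethoxyphenyl and 2,4,6-trichlorophenyl differ at all on this shared core, since neither compound has a number.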